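Three Cytotoxicity Limits and a Benzylsulfanyl Swap

This account rests on a few compounds, and the source may have more. Where it says the series, first, only, none or still open, it means among the compounds named here.

Compound 1, `CCCCCCCCOc1nc(N)nc2c1ncn2/C=C1/CC1(CO)CO`: > 20000 nM, a limit of the assay.
Compound 2, `Nc1nc(N2CCCC2)c2ncn(/C=C3/CC3(CO)CO)c2n1`: > 20000 nM, a limit of the assay.
Compound 3, `CCCCCCOc1nc(N)nc2c1ncn2/C=C1/CC1(CO)CO`: > 20000 nM, a limit of the assay.

The three compounds above were tested in an ADME assay on CCRF-HSB-2 cells (Homo sapiens) for cytotoxicity, with a stated time of 7 days; a higher number here means that more compound is tolerated, a lower number that less compound is tolerated. Compound 1 sits at a limit rather than a number, so where it stands can only be said as that limit. The same holds for compound 2 and for compound 3, and in consequence the steps among them cannot be read: a step that the two limits leave unreadable from compound 1 to compound 2, a step that the two limits leave unreadable from compound 1 to compound 3 and a step that the two limits leave unreadable from compound 2 to compound 3.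

The unmeasured compound 4, `Nc1nc(SCc2ccccc2)c2ncn(/C=C3/CC3(CO)CO)c2n1`, differs from compound 1 as follows: benzylsulfanyl in place of octyloxy on an aromatic carbon. Among the measured compounds shown here, no measured step bears on this change with a readable size. What the data do show is that the series has so far stayed out of reach of the read-out, because of the limit of > 20000 nM in this assay, at which 3 of the 3 values shown sit.

Compound 4 is therefore expected to behave like compound 1 in this assay, with a number no higher from compound 1 to compound 4 (the limit leaves the size open) expected to stay within the usual scatter. Compound 4 is estimated at 20000 nM, between 8000 nM and 40000 nM, and it is quite likely that the assay will again report only a limit for compound 4.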

Compound 4, half-maximal cytotoxic concentration: > 100000 nM
Compound 4: only a limit was reported; the forecaster's own chance of this, stated with the estimate: 75%; at least 5.0-fold (0.69 log units) between middle value and limit.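

In this assay compound 4 gives > 100000 nM, which is a limit of the assay. Among the compounds shown here, compound 1, compound 2 and compound 3 also stand only at limits, so no step from any of them to compound 4 can be read. The compounds shown leave open at what concentration any of the four becomes cytotoxic, and whether benzylsulfanyl in place of octyloxy changes that concentration at all.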